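A few compounds are considered here, and "the series" means these few. Any claim that something is new, unique, unknown or untested is made for them only; others in the source may bear on it.

In an ADME assay (liver) for metabolic stability, with Liver microsome (Rattus norvegicus) as the target, read by LC-MS, using microsomes and NADPH, with stated times of 5 min and 60 min, tested at 4 uM (on this read-out lower numbers stand for a less stable compound and higher numbers for a more stable compound), compound 1 `Cc1c(OCCCCOCOc2ccc(C(=O)O)cc2)ccc(C(=O)CC2CCCC2)c1O` gives 31%, compound 2 `Cc1c(OCCCCOc2ccc(C(=O)O)cc2F)ccc(C(=O)CC2CCCC2)c1O` gives 66%, and compound 3 `CCCC(=O)c1ccc(OCCCCOc2cc(C(=O)O)ccc2OC)c(C)c1O` gives 1%, the lowest of these three numbers. Compound 4 `COc1ccc(C(=O)O)cc1OCCCCOc1ccc(C(=O)CC2CCCC2)c(O)c1C` differs from compound 3 by cyclopentyl in place of ethyl on a saturated chain carbon bound to a carbonyl carbon. For the measured compounds named here, the only measured step, a number 35 percentage points higher from compound 1 to compound 2 (beyond the scatter), is large but lies at another place, so it does not test this change. Still, compound 1 at 31% and compound 2 at 66% both carry (cyclopentylmethyl)carbonyl, so a moderate rise beyond the scatter is expected. The estimated change is a number 19 percentage points higher from compound 3 to compound 4 (beyond the scatter). For compound 4 the expected value is 20%, within an estimated range from 3% to 50%.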

Compound 4, percent of the compound remaining: 14%
Estimate against measurement, compound 4: 6 percentage points above; measured number inside the range.
By their numbers in this assay, from the lowest: compound 3; then compound 4; then compound 1; then compound 2.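

In this assay, cyclopentyl in place of ethyl on a saturated chain carbon bound to a carbonyl carbon gives a number 13 percentage points higher from compound 3 to compound 4 (beyond the scatter), so tested directly, this change brings only a modest rise. With cyclopentyl kept, 5-carboxy-2-methoxyphenyl in place of 4-carboxy-2-fluorophenyl on an oxygen on a saturated carbon gives a number 52 percentage points lower from compound 2 to compound 4 (beyond the scatter), a large fall. In place of (4-carboxyphenoxy)methyl, it gives a number 17 percentage points lower from compound 1 to compound 4 (beyond the scatter), a modest fall.

Nothing here explains these differences. Going by these compounds, whether an amine or a longer chain at the carbonyl-bound carbon would change the number remains open.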